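Compound 4: 2-chloro-6-fluorophenyl replacing 3-chlorophenyl

A few compounds are considered here, and "the series" means these few. Any claim that something is new, unique, unknown or untested is made for them only; others in the source may bear on it.

In a functional assay on cells (Tumor Cell line, Homo sapiens) for cytotoxicity (a higher number here means a weaker inhibitor, a lower number a stronger inhibitor), compound 1 `CN(C)Cc1cc(C(=O)/C=C/c2cccc(Cl)c2)cc(CN(C)C)c1O` gives 4680 nM, the lowest number among the three measured compounds. Compound 2 `CN(C)Cc1cc(C(=O)/C=C/c2ccc(F)cc2)cc(CN(C)C)c1O` gives 20000 nM, and compound 3 `Cc1ccc(/C=C/C(=O)c2cc(CN(C)C)c(O)c(CN(C)C)c2)cc1` gives 17800 nM. Moving away from the 3-chlorophenyl group raised the number both times, by a modest amount: a 4.3-fold higher number from compound 1 to compound 2 (0.63 log units; beyond the scatter) and a 3.8-fold higher number from compound 1 to compound 3 (0.58 log units; beyond the scatter). The third comparison, a 1.1-fold lower number from compound 2 to compound 3 (0.05 log units; within the scatter), does not separate the two compounds.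

Compound 4 `CN(C)Cc1cc(C(=O)/C=C/c2c(F)cccc2Cl)cc(CN(C)C)c1O` changes the same place in the structure: 2-chloro-6-fluorophenyl in place of 3-chlorophenyl on a double-bonded chain carbon bound to a double-bonded chain carbon. Going by the values given here, no measured compound carries the 2-chloro-6-fluorophenyl group, so the measured steps bear on this change only indirectly. Neither of the two higher compounds has a chlorine on this ring, whereas compound 4 keeps one. Among the compounds with values here, with only three compounds, that contrast is thin evidence. The expectation rests on compound 1, at 4680 nM, and on the modest size of a 4.3-fold higher number from compound 1 to compound 2 (0.63 log units; beyond the scatter), which is taken as a rough guide to the size of the change. A small rise is expected, probably smaller than the two measured steps and possibly lost in the scatter. The expected step is a 1.5-fold higher number from compound 1 to compound 4 (0.17 log units; within the scatter). For compound 4 the estimate is 7000 nM, with an expected range of 2800 nM to 17000 nM.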

Compound 4, half-maximal inhibitory concentration: 9120 nM
Compound 4: the middle estimate sits 1.3-fold (0.11 log units) below what was measured; measured number inside the range.
By their numbers in this assay, from the lowest: compounds 1, 4, 3 and 2 (each within the scatter of the next, the first and the last beyond it).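

In this assay, going by these compounds alone, 2-chloro-6-fluorophenyl is the first replacement for 3-chlorophenyl at this position that cannot be told apart from it, with a 1.9-fold higher number from compound 1 to compound 4 (0.29 log units; within the scatter). The same group is separated from 4-fluorophenyl, with a 2.2-fold lower number from compound 2 to compound 4 (0.34 log units; beyond the scatter), but not from 4-methylphenyl, with a 2.0-fold lower number from compound 3 to compound 4 (0.29 log units; within the scatter), so compound 4 is resolved from only one of the three other compounds. The earlier contrast between the chlorine-bearing ring of compound 1 and the chlorine-free rings of compound 2 and compound 3 therefore holds only in part: compound 1 and compound 4 are not separated, and neither are compound 3 and compound 4, which goes against any clean split by chlorine.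

The compounds shown do not settle whether chlorine, fluorine or the placement of either on the ring accounts for these differences, and no measurement on hand offers an explanation. Also open, as far as these compounds go, is how this position would respond to a methoxy group, a nitrile or a carboxylic acid on the ring, or to an amine in place of the ring, as all four groups measured here are halogen- or methyl-substituted phenyl rings.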